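Working notes: the step from compound 2 to compound 4

The source may report more compounds than this note shows. Statements on the series, on what has been measured and on what is new or still open speak of the compounds shown alone.

Read-out for this series: an in vivo ADME assay on the whole organism for pharmacokinetics, with Rattus norvegicus as the target, at a dose of 5 mg/kg by the oral route; on this read-out higher numbers stand for higher oral bioavailability and lower numbers for lower oral bioavailability
compound 1 `Cc1ccc([C@H](C(=O)N(C)C)N2C(=O)[C@@H](C3Cc4ccccc4C3)NC(=O)[C@H]2CC(C)C)cn1` gives 57%
compound 2 `CC[C@H](C)[C@@H]1C(=O)N[C@H](C2Cc3ccccc3C2)C(=O)N1[C@@H](C(=O)N(C)C)c1ccc(C)nc1C` gives 84%
compound 3 `Cc1ccc([C@H](C(=O)N2CCCC2)N2C(=O)[C@@H](C3Cc4ccccc4C3)NC(=O)[C@H]2CC(C)C)cn1` gives 36%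

Compound 2 stands highest of the three in this assay, and its gaps to compound 1 and compound 3 both lie beyond the scatter. Compound 4 `CC[C@H](C)[C@@H]1C(=O)N[C@H](C2Cc3ccccc3C2)C(=O)N1[C@@H](C(=O)N(C)C)c1ccc(C)[n+]([O-])c1` has not been measured yet. The change from compound 2 to compound 4 is a group of 8 heavy atoms (6 carbon, 1 nitrogen, 1 oxygen; one six-membered aromatic ring with 1 hetero atom) in place of a group of 8 heavy atoms (7 carbon, 1 nitrogen; one six-membered aromatic ring with 1 hetero atom), on a saturated chain carbon bound to an amide-type nitrogen in a ring and a carbonyl carbon and the 2,6-dimethylpyridin-3-yl group is what leaves.

For the measured compounds named here, the only measured single-place step is a number 21 percentage points lower from compound 1 to compound 3 (beyond the scatter) and it lies elsewhere in the structure, on a carbonyl carbon. It serves only as a gauge of size, showing that one change can move this read-out beyond the scatter. Going by the values given here, no measured step touches the group that changes here. With compound 2 at 84% there is more room downward than upward, so a fall is expected. The expected step is a number 39 percentage points lower from compound 2 to compound 4 (beyond the scatter) and it is somewhat larger than the measured one, though with wide uncertainty. For compound 4 the estimate is 45% (expected range 20% to 72%).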

Compound 4, oral bioavailability: < 1%
Compound 4 ended at the assay's limit; the forecaster's own chance of this, stated with the estimate: 2%; middle value at least 44 percentage points away from the limit.
By their numbers in this assay, from the lowest: compound 3; then compound 1; then compound 2. At a limit, below all of these: compound 4.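

In this assay, the exchange at the saturated chain carbon bound to an amide-type nitrogen in a ring and a carbonyl carbon gives a number at least 83 percentage points lower from compound 2 to compound 4 (beyond the scatter). The groups that leave and enter match in heavy-atom count, ring type, hydrogen-bond donors, hydrogen-bond acceptors and net charge, so these counts do not separate the large step here from the modest one on a carbonyl carbon, a number 21 percentage points lower from compound 1 to compound 3 (beyond the scatter). Compound 4 sits at a limit of the assay and not at a number: the limit of < 1% in this assay, at which 1 of the 4 values shown sits.

The compounds shown do not separate the gain of the oxygen from the loss of a carbon in this exchange. They also leave open how an amine or a carboxylic acid on the six-membered aromatic ring would read in this assay.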